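Phenyl to Naphthyl: A Step Without a Precedent

The source may hold more compounds than are shown below. What is called first, only, known or untested is meant among the compounds shown, and "the series" means these compounds.

Measured so far:
- compound 1, `COc1ccc(C2CC(c3ccccc3)=NN2C2=NC(=O)/C(=C3\C(=O)Nc4ccccc43)S2)cc1`: 1640 nM
- compound 2, `COc1ccc(C2CC(c3ccccc3)=NN2C2=NC(=O)/C(=C3\C(=O)Nc4ccc(Br)cc43)S2)cc1`: 250 nM

Both compounds were tested in a functional assay on cells (Leukemia cell, Homo sapiens) for cytotoxicity, read by sulforhodamine B assay, with a stated time of 48 h; on this read-out higher numbers stand for weaker inhibition of growth and lower numbers for stronger inhibition of growth. Compound 1 gives 1640 nM there, and compound 2 gives 250 nM, the lowest of the two numbers. Among the compounds with values here, the only measured step is a 6.6-fold lower number from compound 1 to compound 2 (0.82 log units; beyond the scatter), which concerns a different position from the one changed next.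

Compound 3, `COc1ccc(C2CC(c3ccc4ccccc4c3)=NN2C2=NC(=O)/C(=C3\C(=O)Nc4ccc(Br)cc43)S2)cc1`, differs from compound 2 by naphthalen-2-yl in place of phenyl on a carbon with a double bond to nitrogen. Within the data shown here, no measured pair changes this group, so the bromo step gives no guidance on its size or direction. With nothing in the data pointing either way, compound 3 is expected to stay close to compound 2, with a step of no change at the digits printed from compound 2 to compound 3 (within the scatter) in this assay, that is, no change beyond the scatter. The estimated value for compound 3 is therefore 250 nM, with a range from 80 nM to 800 nM.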

Compound 3, concentration for 50% growth inhibition: 130 nM
Estimate against measurement, compound 3: 1.9-fold (0.28 log units) above, within the range that was stated.
By their numbers in this assay, from the lowest: compounds 3 and 2 (each within the scatter of the next); then compound 1.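

Putting naphthalen-2-yl in place of phenyl on the carbon with a double bond to nitrogen adds a second six-membered aromatic ring, yet in this assay it gives a 1.9-fold lower number from compound 2 to compound 3 (0.28 log units; within the scatter). This position therefore accepts a group of 10 heavy atoms instead of 6 with no change beyond the scatter, something the earlier bromo step, made elsewhere on the molecule, could not show. Nothing available here bears on why the two groups read alike.

From the compounds shown here alone, it remains open whether this carbon would also accept a group of a different kind, such as an amine or a carboxylic acid carried on the phenyl. Going by these compounds, it is equally open whether naphthalen-2-yl would read the same way on the core of compound 1, which carries hydrogen instead of bromo.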